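A Second Allyl Group on Compound 2

The source may report more compounds than this note shows. Statements on the series, on what has been measured and on what is new or still open speak of the compounds shown alone.

In a functional assay on MCF7 cells (Homo sapiens) for inhibition (a higher number here means a weaker inhibitor, a lower number a stronger inhibitor), compound 1 (`CCCCCCCC[C@@]1(C)SC(O)=C(C)C1=O`) gives 16.5 ug/mL as its half-maximal inhibitory concentration. Compound 2 (`C=CCC1(C)C(=O)S[C@](C)(CCCCCCCC)C1=O`) reads > 50 ug/mL as a limit and not a number. Compound 3 (`C=CCC1(CC=C)C(=O)S[C@](C)(CCCCCCCC)C1=O`) carries vinyl in place of hydrogen on a saturated chain carbon bound to a saturated ring carbon, which also reads as methyl to allyl. Among the measured compounds shown here, no measured step shows what this change does, so in this assay no step beyond the scatter is expected, in either direction. The expected step is a step that the limit leaves unreadable from compound 2 to compound 3 by this estimate. Compound 3 is expected at 60 ug/mL with 35 ug/mL to 120 ug/mL as the estimated range.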

Compound 3, half-maximal inhibitory concentration: > 50 ug/mL
Compound 3: only a limit was reported (the forecaster's own chance of this, stated with the estimate: 80%); the middle value is on the limit's open side.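

No step can be read from compound 2 to compound 3, because each gives only a limit and not a number in this assay: the limit of > 50 ug/mL in this assay, at which 2 of the 3 values shown sit.

The compounds shown leave open whether the change from methyl to allyl alters inhibition at all.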